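Losing the methoxycarbonyl from compound 1

A few compounds are considered here, and "the series" means these few. Any claim that something is new, unique, unknown or untested is made for them only; others in the source may bear on it.

In a functional assay on HCT-116 cells (Homo sapiens) for inhibition, read by MTT assay, with a stated time of 48 h (a higher number here means a weaker inhibitor, a lower number a stronger inhibitor), compound 1 (`COC(=O)c1cc(CNc2cc(OC)c(OC)c(OC)c2)ccc1OC`) reads 38100 nM and stands level, within the scatter, with compound 3 (`COc1ccc(N(Cc2cc(OC)c(OC)c(OC)c2)C(=O)CN=[N+]=[N-])cc1O`) at 38800 nM in the same assay. Compound 2 (`COc1ccc(CN(C(=O)CCl)c2cc(OC)c(OC)c(OC)c2)cc1O`) at 250 nM lies far lower than both, so compound 1 sits at the weak end of this small set.

Compound 4 (`COc1ccc(CNc2cc(OC)c(OC)c(OC)c2)cc1`) differs from compound 1 in one place: hydrogen in place of methoxycarbonyl on an aromatic carbon with hydrogen in place of methoxycarbonyl on an aromatic carbon, ortho to a methoxy group and meta to a large group. Within the data shown here, no measured pair isolates this change, so its size cannot be read from the data. The closest reference is compound 1 itself (38100 nM), and the expectation stays near that number. The estimated step is a 1.3-fold lower number from compound 1 to compound 4 (0.10 log units; within the scatter) and no change beyond the scatter is expected, in either direction. In this assay the estimate for compound 4 is 30000 nM (expected range 10000 nM to 90000 nM).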

Compound 4, half-maximal inhibitory concentration: 18400 nM
Compound 4: middle estimate off by 1.6-fold (0.21 log units), on the high side; low and high end bracket the measured number.
By their numbers in this assay, from the lowest: compound 2; then compound 4; then compounds 1 and 3 (each within the scatter of the next).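

In this assay, among these compounds, replacing the methoxycarbonyl with hydrogen on this aromatic carbon, ortho to a methoxy group and meta to a large group, gives a 2.1-fold lower number from compound 1 to compound 4 (0.32 log units; beyond the scatter) and so provides the first direct reading of this position. The step is modest, but it shows that the methoxycarbonyl is not required here for the activity read in this assay, and that plain hydrogen gives the lower number of the pair. No measurement among these compounds accounts for the step.

Going by these compounds, whether a carboxylic acid or an amine on the same carbon would lower the number further or raise it remains open. Also open, on these data alone, is whether the step would carry over to other compounds.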